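The source may report more compounds than this note shows. Statements on the series, on what has been measured and on what is new or still open speak of the compounds shown alone.

Of the compounds shown here, two from this series have been tested in a functional assay on HCT-116 cells (Homo sapiens) for cytotoxicity, read by MTT assay, with a stated time of 72 h (a lower number here means a stronger inhibitor of growth, a higher number a weaker inhibitor of growth), and a third awaits measurement. Among the compounds with values here, compound 1 `COc1cc(OC)c(/C=C/S(=O)(=O)Cc2ccc(OC)c([N+](=O)[O-])c2)c(OC)c1` gives 660 nM in this assay, the only actual number on record here. Compound 2 `COc1cc(OC)c(/C=C/[S+]([O-])Cc2ccc(OC)c(N)c2)c(OC)c1` is the other tested compound, and in this assay compound 2 gives < 10 nM, which is a limit of the assay rather than a number. Within the data shown here, compound 2 differs from compound 1 in more than one place, so the two values show only that one is a number and the other a limit (the limit of < 10 nM in this assay, at which 1 of the 2 values shown sits).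

Compound 3 `COc1cc(OC)c(/C=C/S(=O)(=O)Cc2ccc(OC)c(N)c2)c(OC)c1` is the untested compound. It differs from compound 1 in a single place: amino in place of nitro on an aromatic carbon. Compound 2 also carries the amino group, and the limit it reaches in this assay suggests that this group is compatible with strong inhibition of growth. On that basis compound 3 is expected to show a large step downward in this assay, estimated as a 26-fold lower number from compound 1 to compound 3 (1.42 log units; beyond the scatter). The estimated value for compound 3 is 25 nM, with a likely range from 5 nM to 120 nM.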

Compound 3, concentration for 50% growth inhibition: < 10 nM
Compound 3: a limit, no number; the forecaster's own chance of this, stated with the estimate: 25%; at least 2.5-fold (0.39 log units) between middle value and limit.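

Within the data shown here, replacing nitro with amino on an aromatic carbon, ortho to a methoxy group and meta to a large group, is the only change here, and in this assay it gives an at least 66-fold lower number from compound 1 to compound 3 (1.81 log units; beyond the scatter). Among these compounds, the amino group had previously been seen only in a compound that differed from compound 1 in more than one place, so its share of the activity could not be separated from the other difference; this step ties a large change to this single position. In this assay compound 3 gives < 10 nM, which is a limit of the assay and not a number, so the step gives only a minimum size and the strong end of the series cannot be resolved: the limit of < 10 nM in this assay, at which 2 of the 3 values shown sit.

With only nitro and amino shown at this position, it remains open whether the amino group itself favours growth inhibition or whether removing nitro is enough. A hydroxyl group, a methyl group or an acetylated amine at the same place would help separate these two readings, while an assay reading beyond the limit would be needed to put numbers on compound 2 and compound 3.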